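Swapping the benzylic aryl group in a pyridyl ether amide series

The source may hold more compounds than are shown below. What is called first, only, known or untested is meant among the compounds shown, and "the series" means these compounds.

Compound 1, `CC(Oc1cccnc1Nc1cnn(C)c1)c1cccc(C(=O)NCc2ccc(OC(F)(F)F)cc2)c1`, in a functional assay on HCC78 cells (Homo sapiens) for antiproliferative activity, read by MTT assay, with a stated time of 48 h; on this read-out higher numbers stand for weaker inhibition and lower numbers for stronger inhibition: 73900 nM
Compound 2, `CC(Oc1cccnc1Nc1cnn(C)c1)c1cccc(C(=O)NCc2ccc(F)c(Cl)c2)c1`, in this assay: 7800 nM
Compound 3, `CC(Oc1cccnc1Nc1cnn(C)c1)c1cccc(C(=O)NCc2ccc(Cl)c(C(F)(F)F)c2)c1`, in this assay: 48600 nM

Compound 3 gives the second highest of the three numbers in this assay. Its nearest neighbour is compound 1, and the gap between them, a 1.5-fold lower number from compound 1 to compound 3 (0.18 log units; within the scatter), is within the scatter. Its furthest neighbour is compound 2, separated by a 6.2-fold higher number from compound 2 to compound 3 (0.79 log units; beyond the scatter). Among the compounds with values here, the one clearly resolved change in this set is a 9.5-fold lower number from compound 1 to compound 2 (0.98 log units; beyond the scatter).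

Compound 4, `CC(Oc1cccnc1Nc1cnn(C)c1)c1cccc(C(=O)NCc2ccccc2S(=O)(=O)C(C)C)c1`, differs from compound 3 by 2-(isopropylsulfonyl)phenyl in place of 4-chloro-3-(trifluoromethyl)phenyl on a saturated chain carbon bound to an amide-type nitrogen. All three measured steps change the aryl group on the same saturated chain carbon bound to an amide-type nitrogen, so they bear on this step, and they span from within the scatter up to modest movements in either direction. None of them, however, introduces a group resembling 2-(isopropylsulfonyl)phenyl, with its two hydrogen-bond acceptors, so the direction of the present step is not fixed by the data. The expected outcome for compound 4 in this assay is therefore a step of about the size of the measured ones, leaning toward a lower number, a 3.2-fold lower number from compound 3 to compound 4 (0.51 log units; beyond the scatter), with wide uncertainty. The estimate for compound 4 is 15000 nM, expected to fall between 3000 nM and 80000 nM.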

Compound 4, half-maximal inhibitory concentration: 63100 nM
Beside the measured number, compound 4's estimate is 4.2-fold (0.62 log units) below it; the measured number falls inside the stated range.
By their numbers in this assay, from the lowest: compound 2; then compounds 3, 4 and 1 (each within the scatter of the next).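

In this assay, placing 2-(isopropylsulfonyl)phenyl on the saturated chain carbon bound to an amide-type nitrogen gives a 1.3-fold higher number from compound 3 to compound 4 (0.11 log units; within the scatter) and a 1.2-fold lower number from compound 1 to compound 4 (0.07 log units; within the scatter) so compound 4 cannot be told apart from compound 3 or compound 1. Within the data shown here, a sulfonyl-bearing aryl group, unlike any of the earlier aryl groups at this position, thus joins the two fluorinated groups of compound 1 and compound 3 in one band of numbers, while the step to the 3-chloro-4-fluorophenyl compound, an 8.1-fold higher number from compound 2 to compound 4 (0.91 log units; beyond the scatter) leaves compound 2 as the only member of the four that is separated from the rest, and the strongest of them. Nothing measured in this set accounts for either the shared band or the separation of compound 2.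

The compounds shown leave open whether an unsubstituted phenyl group at this position would stand with compound 2 or with the other three. They also leave open how an aryl group carrying an amine or a carboxylic acid would read in this assay and whether any such group could move the number past that of compound 2.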